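The source may report more compounds than this note shows. Statements on the series, on what has been measured and on what is new or still open speak of the compounds shown alone.

Measured in an assay on isolated protein for inhibition of thyroid hormone receptor beta (Homo sapiens), read by fluorescence polarization; on this read-out lower numbers stand for stronger inhibition and higher numbers for weaker inhibition:
- compound 1 `CS(=O)(=O)c1ccc(C(=O)N2CCC(C(=O)N(Cc3ccccc3)c3ccccc3)CC2)cc1[N+](=O)[O-]`; compound 1 gives > 60000 nM, a limit of the assay
- compound 2 `CS(=O)(=O)c1ccc(C(=O)N2CCC(C(=O)N3CCc4ccccc43)CC2)cc1[N+](=O)[O-]`; compound 2 gives > 60000 nM, a limit of the assay
- compound 3 `CS(=O)(=O)c1ccc(C(=O)N2CCC(C(=O)N3CCN(c4ccc(F)cc4)CC3)CC2)cc1[N+](=O)[O-]`; compound 3 gives > 60000 nM, a limit of the assay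

Within the data shown here, compound 2 stands nowhere distinct: its result is a limit, not a number, and the same holds for every other compound measured so far, as summarised by the limit of > 60000 nM in this assay, at which 3 of the 3 values shown sit. Among the measured compounds shown here, no two measured compounds differ in only one place, so no measured step is available to calibrate what a change at the amide next to the saturated ring does in this assay.

Compound 4 `CN(Cc1ccccc1)C(=O)C1CCN(C(=O)c2ccc(S(C)(=O)=O)c([N+](=O)[O-])c2)CC1` is the next compound to be tested. It differs from compound 2 by benzyl(methyl)amino in place of 2,3-dihydro-1H-indol-1-yl on a carbonyl carbon whose other neighbour is a saturated ring carbon. Compound 1 already carries an open, benzyl-bearing amide and still sits at the limit, and compound 3 with its piperazine amide sits there too, so the data give no sign that the shape of this amide substituent moves the read-out at all.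

The expectation is therefore no step beyond the scatter and, most likely, another limit. Compound 4 is expected at 80000 nM, within 30000 nM to 250000 nM. The step from compound 2 to compound 4 is estimated as a step that the limit leaves unreadable from compound 2 to compound 4, i.e. no change that the assay could resolve.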

Compound 4, half-maximal inhibitory concentration: > 60000 nM
Compound 4 gave a limit, no number; the forecaster's own chance of this, stated with the estimate: 85%; the middle value lies beyond the limit too.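

In this assay compound 4 gives > 60000 nM, a limit of the assay and not a number. Neither the step from compound 2 to compound 4 nor the one from compound 1 to compound 4 can be read, as all four compounds share one limit: the limit of > 60000 nM in this assay, at which 4 of the 4 values shown sit.

The compounds shown leave open whether any amide substituent on the shared core gives a readable number.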